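A few compounds are considered here, and "the series" means these few. Any claim that something is new, unique, unknown or untested is made for them only; others in the source may bear on it.

Measured compounds in a functional assay on PC-3 cells (Homo sapiens) for inhibition; a lower number here means a stronger inhibitor, a higher number a weaker inhibitor:
compound 1 `Cc1c(C(=O)N/N=C\c2cc(O)ccc2O)oc2cccc(O)c12`, 95500 nM;
compound 3 `Cc1ccc(O)c(/C=N\NC(=O)c2oc3cccc(O)c3c2C)c1`, 7350 nM.
For compound 2 `Cc1c(C(=O)N/N=C\c2ccc(O)c(O)c2O)oc2cccc(O)c12` this assay gives only a limit, >= 40000 nM, not a number.

Compound 2 therefore stands at the limit of >= 40000 nM in this assay, at which 1 of the 3 values shown sits, the weak end of the numbers shown, and its distance to compound 1 or compound 3 is not known. Compound 4 `Cc1c(C(=O)N/N=C\c2cccc(O)c2O)oc2cccc(O)c12` differs from compound 2 in one place: hydrogen in place of hydroxy on an aromatic carbon. Going by the values given here, the one measured step that bears on this is a 13-fold lower number from compound 1 to compound 3 (1.11 log units; beyond the scatter), where a hydroxy also left an aromatic carbon of the same ring and the number fell well beyond the scatter. A fall beyond the scatter is expected here too, though the entering group differs, so a smaller step is estimated. The step estimated is a number no higher from compound 2 to compound 4 (the limit leaves the size open). Compound 4 is expected at 40000 nM, between 12000 nM and 130000 nM.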

Compound 4, half-maximal inhibitory concentration: 12200 nM
Compound 4: the middle estimate sits 3.3-fold (0.52 log units) above what was measured; the measured number falls inside the stated range.
By their numbers in this assay, from the lowest: compounds 3 and 4 (each within the scatter of the next); then compound 1.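

Compound 2 is held only by a limit: the limit of >= 40000 nM in this assay, at which 1 of the 4 values shown sits.

Hydrogen in place of hydroxy para to a large group still gives an at least 3.2-fold lower number from compound 2 to compound 4 (0.51 log units; beyond the scatter), so the number can fall with no methyl entering. The 2,3-dihydroxyphenyl group gives a 7.8-fold lower number from compound 1 to compound 4 (0.89 log units; beyond the scatter), so where the second hydroxy sits counts, while against 2-hydroxy-5-methylphenyl it gives a 1.7-fold higher number from compound 3 to compound 4 (0.22 log units; within the scatter), a step that stays within the scatter.

As far as these compounds go, the full size of the step from the limit stays open. Also open, from the compounds shown here alone, is what an amine or a carboxylic acid would give on this aromatic carbon.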